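The source may report more compounds than this note shows. Statements on the series, on what has been measured and on what is new or still open speak of the compounds shown alone.

The measured compounds, tested in a functional assay on CCRF-CEM cells (Homo sapiens) for inhibition, read by cell counting, with a stated time of 3 days; a higher number here means a weaker inhibitor, a lower number a stronger inhibitor:

compound 1, `C=C(Br)C(=O)Nc1cccc(-c2cn3nc(Cc4ccccc4)sc3n2)c1`, 4200 nM
compound 2, `Nc1cccc(-c2cn3nc(Cc4ccccc4)sc3n2)c1`, 37000 nM
compound 3, `C=C(Br)C(=O)Nc1cccc(-c2cn3nc(-c4cccc(OC)c4)sc3n2)c1`, 1200 nM

Compound 1 and compound 2 share a core and differ in one place: hydrogen in place of (1-bromoethenyl)carbonyl on a nitrogen on an aromatic ring. This change gives an 8.8-fold higher number from compound 1 to compound 2 (0.94 log units; beyond the scatter). Compound 3 differs from compound 1 in the core: 3-methoxyphenyl in place of benzyl on an aromatic carbon, and this gives a 3.5-fold lower number from compound 1 to compound 3 (0.54 log units; beyond the scatter). Compound 3 thus stands lowest of the three in this assay.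

Compound 4, `COc1cccc(-c2nn3cc(-c4cccc(N)c4)nc3s2)c1`, is not yet measured in this assay. It differs from compound 3 in the same way that compound 2 differs from compound 1: hydrogen in place of (1-bromoethenyl)carbonyl on a nitrogen on an aromatic ring. The place of the change is the same word for word in both pairs, so the change is the same one, made on the core of compound 3 instead of the core of compound 1.

Because an 8.8-fold higher number from compound 1 to compound 2 (0.94 log units; beyond the scatter) was seen for the same change, a step of similar size is expected for compound 4, namely an 8.3-fold higher number from compound 3 to compound 4 (0.92 log units; beyond the scatter). On that basis compound 4 is estimated at 10000 nM in this assay, with a likely range from 4000 nM to 30000 nM.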

Compound 4, half-maximal inhibitory concentration: > 250000 nM
Compound 4: only a limit was reported; the forecaster's own chance of this, stated with the estimate: 10%; at least 25-fold (1.39 log units) between middle value and limit.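

In this assay the loss of the (1-bromoethenyl)carbonyl group, leaving a free amino group, raises the number on both cores, and the new step is an at least 200-fold higher number from compound 3 to compound 4 (2.31 log units; beyond the scatter). The direction of the change carried over from one core to the other, but its size did not: the same change on two cores in this assay, an 8.8-fold higher number (0.94 log units; beyond the scatter) from compound 1 to compound 2 and an at least 200-fold higher number (2.31 log units; beyond the scatter) from compound 3 to compound 4, at least 23-fold (1.37 log units) apart, beyond the scatter of two such steps

As far as these compounds go, compound 4 gives > 250000 nM, which is a limit of the assay and not a number, so the full size of its step stays unknown, and two pairs show neither why the cores differ nor how the change would behave on any other core.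

The compounds shown leave open whether the bromine or the rest of the (1-bromoethenyl)carbonyl group carries the gain, a question that an acetyl group or an unbrominated propenoyl group on the same nitrogen would address. They also leave open how the change would behave with a plain phenyl group or a longer chain in place of the benzyl or 3-methoxyphenyl group.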